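Working notes: from compound 1 to compound 3

The compounds below may be only part of what the source reports. "The series", "measured", "known", "first", "only" and "open" are said of these compounds alone.

Compounds in a functional assay on HeLa cells (Homo sapiens) for inhibition, read by MTT assay, with a stated time of 72 h; on this read-out lower numbers stand for stronger inhibition and higher numbers for weaker inhibition
- compound 1 `COc1cc(OC)c(C(=O)/C=C/c2ccccc2OC)c(OC)c1` gives 19600 nM
- compound 2 `COc1cc(OC)c(C(=O)/C=C/c2ccccc2[N+](=O)[O-])c(OC)c1` gives 9000 nM
- compound 3 `COc1cc(OC)c(C(=O)/C=C/c2ccc(N)cc2)c(OC)c1` has not yet been measured

Of the two measured compounds, compound 1 has the higher number, 19600 nM in this assay and therefore the weaker inhibition. The next structural change is 4-aminophenyl in place of 2-methoxyphenyl on a double-bonded chain carbon bound to a double-bonded chain carbon on the same shared core, with 4-aminophenyl in place of 2-methoxyphenyl on a double-bonded chain carbon bound to a double-bonded chain carbon.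

Going by the values given here, only one measured step bears on this change. It is a 2.2-fold lower number from compound 1 to compound 2 (0.34 log units; beyond the scatter) and comes from nitro in place of methoxy on an aromatic carbon. That step is modest and shows that this aromatic substituent can move the number. Among the compounds with values here, it is only indirect evidence, as no measured compound carries the 4-aminophenyl group.

A modest step towards a lower number is therefore expected, and the direction remains uncertain. The working expectation is a 2.5-fold lower number from compound 1 to compound 3 (0.39 log units; beyond the scatter) in this assay and no large change. For compound 3 the estimated value is 8000 nM with an expected range from 2500 nM to 20000 nM in this assay for now.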

Compound 3, half-maximal inhibitory concentration: > 50000 nM
Compound 3 ended at the assay's limit; the forecaster's own chance of this, stated with the estimate: 5%; at least 6.2-fold (0.79 log units) between middle value and limit.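

In this assay compound 3 stands at a limit of the assay, > 50000 nM, and this is a limit and not a number. Going by these compounds alone, the exchange of 2-methoxyphenyl for 4-aminophenyl gives an at least 2.5-fold higher number from compound 1 to compound 3 (0.40 log units; beyond the scatter), the first step towards a higher number, while the only earlier step, a 2.2-fold lower number from compound 1 to compound 2 (0.34 log units; beyond the scatter), ran the other way. The aromatic group on this double-bonded chain carbon can therefore move the number in either direction in this assay, but the upward step can be read only as a minimum size, set by the ceiling of the measurement: the limit of > 50000 nM in this assay, at which 1 of the 3 values shown sits.

The step from compound 1 to compound 3 replaces one whole aromatic group with another, and the compounds shown do not separate the effect of exchanging methoxy for the amine from the effect of where that group sits on the ring. As far as these compounds go, a 2-aminophenyl or a 4-methoxyphenyl group on the same chain carbon would pull these two apart, and how far compound 3 lies past its limit remains unknown.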